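This account rests on a few compounds, and the source may have more. Where it says the series, first, only, none or still open, it means among the compounds named here.

Measured so far:
- Compound 1, `c1ccc2c(c1)CN[C@@H](CN(CC1CCNCC1)[C@H]1CCCc3cccnc31)C2`: 65 nM
- Compound 2, `c1ccc2c(c1)CN[C@@H](CN(CC[C@@H]1CCCNC1)[C@H]1CCCc3cccnc31)C2`: 161 nM

Both compounds were tested in a functional assay on CCRF-CEM cells for antagonist activity at C-X-C chemokine receptor type 4 (Homo sapiens), read by calcium flux, with stated times of 25 min and 90 s; a higher number here means a weaker inhibitor, a lower number a stronger inhibitor. Compound 1 has the lowest of the two numbers, with compound 2 the nearest at a 2.5-fold higher number from compound 1 to compound 2 (0.39 log units; beyond the scatter). That step swapped the group on a saturated chain carbon bound to an amine nitrogen.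

Compound 3, `c1ccc2c(c1)CN[C@@H](CN(CCN1CCNCC1)[C@H]1CCCc3cccnc31)C2`, has not yet been measured in this assay. It differs from compound 1 in the same place, as follows: (piperazin-1-yl)methyl in place of piperidin-4-yl on a saturated chain carbon bound to an amine nitrogen

Within the data shown here, the only step that bears on this change is the one from compound 1 to compound 2, which also replaced the piperidin-4-yl group with a ring attached through an extra chain carbon and gave a modestly higher number. Since the new group in compound 3 likewise adds a chain carbon and moves the ring nitrogen, a modest rise in the same direction is expected, a 2.0-fold higher number from compound 1 to compound 3 (0.30 log units; within the scatter). Compound 3 is therefore estimated at 130 nM, within the range 50 nM to 400 nM.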

Compound 3, half-maximal inhibitory concentration: 553 nM
Beside the measured number, compound 3's estimate is 4.3-fold (0.63 log units) below it; measured number above the stated range.
By their numbers in this assay, from the lowest: compound 1; then compound 2; then compound 3.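

Measured in this assay the change from piperidin-4-yl to (piperazin-1-yl)methyl gives an 8.5-fold higher number from compound 1 to compound 3 (0.93 log units; beyond the scatter) and so shows that this position on a saturated chain carbon bound to an amine nitrogen can lose far more than the earlier change suggested. The second comparison holds the chain fixed and changes only the ring, from piperidin-3-yl to piperazin-1-yl, and it still gives a 3.4-fold higher number from compound 2 to compound 3 (0.54 log units; beyond the scatter) so the added chain carbon is not the whole story. The ring itself matters here, and of the rings shown, the one with two nitrogens gives the highest number.

Still open, as far as these compounds go, is how a 2-(piperidin-4-yl)ethyl group, or a morpholin-4-yl ring on the same chain, would compare. Nothing measured here explains these rises.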